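Biphenyl-triazole amides: shortened chain with benzylic pyridine amide

This account rests on a few compounds, and the source may have more. Where it says the series, first, only, none or still open, it means among the compounds named here.

Compound 2 `O=C(CCCCCCCc1cn(-c2ccccc2-c2ccccc2)nn1)Nc1cccnc1` gives 111% in a functional assay on SH-SY5Y cells (Homo sapiens) for cytotoxicity, read by MTT assay, with a stated time of 48 h, tested at 10 uM (on this read-out lower numbers stand for a stronger effect and higher numbers for a weaker effect at the one concentration tested), the highest of the three numbers in hand. Compound 3 `O=C(CCCCCCCCc1cn(-c2cnc3ccccc3c2)nn1)Nc1ccncc1` gives 53% and compound 1 `O=C(CCCCCCCCc1cn(-c2cnc3ccccc3c2)nn1)NCc1cccnc1` gives 29%; both are well apart from compound 2, beyond the scatter. Compound 4 `O=C(CCCCCc1cn(-c2ccccc2-c2ccccc2)nn1)NCc1cccnc1` is unmeasured and differs from compound 2 as follows: a group of 10 heavy atoms (7 carbon, 2 nitrogen, 1 oxygen; one six-membered aromatic ring with 1 hetero atom) in place of a group of 11 heavy atoms (8 carbon, 2 nitrogen, 1 oxygen; one six-membered aromatic ring with 1 hetero atom), on a saturated chain carbon, five bonds along the chain from an aromatic carbon. Within the data shown here, the only step on the amide side that bears on it is on the core of compound 1: a number 24 percentage points higher from compound 1 to compound 3 (beyond the scatter). Read in reverse, moving from a directly attached ring to the (pyridin-3-yl)methyl group should lower the number modestly; the shortened chain has no precedent here. Compound 4 is therefore expected at 90% (range 60% to 115%), a step of a number 21 percentage points lower from compound 2 to compound 4 (beyond the scatter).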

Compound 4, a percentage reported as activity, at one concentration (the size of the read-out at that concentration, not a potency): 12.5%
Beside the measured number, compound 4's estimate is 77.5 percentage points above it, and the stated range ends above it.
By their numbers in this assay, from the lowest: compound 4; then compound 1; then compound 3; then compound 2.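

Exchanging the group at this saturated chain carbon gives a number 98.5 percentage points lower from compound 2 to compound 4 (beyond the scatter) in this assay and shows that the read-out on the core of compound 2 responds strongly to this place. The exchange shortens the chain and installs ((pyridin-3-yl)methyl)carbamoyl in one step, and it is large, whereas the amide-side change on the core of compound 1, running the opposite way, is modest at a number 24 percentage points higher from compound 1 to compound 3 (beyond the scatter). Nothing measured here explains the step. Still open, from the compounds shown here alone, is how much of the step belongs to chain length alone. Also open, going by these compounds, is whether a carboxylic acid or a primary amine at this carbon would keep the low number.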